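The source may hold more compounds than are shown below. What is called first, only, known or untested is meant among the compounds shown, and "the series" means these compounds.

Of the compounds shown here, two have been measured so far in an assay on LX2 cells for inhibition of COL1A1 promoter (Homo sapiens), read by a luciferase reporter, with a stated time of 24 h, tested at 50 uM; on this read-out higher numbers stand for a stronger effect at the one concentration tested and lower numbers for a weaker effect. Compound 1 `Cc1cc(-n2cc(C(=O)Nc3cc(F)cc(F)c3)c(=O)c3ccc(N(C)C)nc32)ccc1OCCCCCCC[N+]1(C)CCCC1` gives 35.9% in this assay. Going by the values given here, compound 2 `CN(C)c1ccc2c(=O)c(C(=O)Nc3cc(F)cc(F)c3)cn(-c3ccc(OCCCCCCC[N+]4(C)CCCC4)c(Cl)c3)c2n1`, which carries a chloro in place of the methyl on an aromatic carbon, gives 2.59% in this assay; the step of a number 33.3 percentage points lower from compound 1 to compound 2 (beyond the scatter) leaves compound 2 with the lowest of the two numbers, and compound 1 is its only neighbour.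

Compound 3 `CN(C)c1ccc2c(=O)c(C(=O)Nc3cc(F)cc(F)c3)cn(-c3ccc(OCCCCCCC[N+]4(C)CCCCC4)c(Cl)c3)c2n1` has not yet been measured. It differs from compound 2 in a single place: a group of 7 heavy atoms (6 carbon, 1 nitrogen; one six-membered non-aromatic ring with 1 hetero atom) in place of a group of 6 heavy atoms (5 carbon, 1 nitrogen; one five-membered non-aromatic ring with 1 hetero atom), on a saturated chain carbon, seven bonds along the chain from an oxygen on an aromatic ring. Among the compounds with values here, no measured step touches this part of the structure; the only measured step, a number 33.3 percentage points lower from compound 1 to compound 2 (beyond the scatter), concerns a substituent on an aromatic carbon and says nothing about swapping the five-membered non-aromatic ring for a six-membered one on the saturated chain. With nothing to point in either direction, the expected step in this assay is a number 2.4 percentage points higher from compound 2 to compound 3 (within the scatter), that is, no change beyond the scatter is expected. Compound 3 is therefore estimated to give 5% in this assay, with a range from -8% to 20%.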

Compound 3, a percentage reported as inhibition, at one concentration (the size of the read-out at that concentration, not a potency): "not active" (no number reported)
Nothing numeric was reported for compound 3; there is nothing to compare the estimate with.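

Compound 3 is reported only as "not active" in this assay with no number, so no step can be read from compound 2 to compound 3. No other measurement shown bears on this result. As far as these compounds go, whether the six-membered ring in place of the five-membered ring changes the read-out at all remains open.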